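A few compounds are considered here, and "the series" means these few. Any claim that something is new, unique, unknown or untested is made for them only; others in the source may bear on it.

Compound 2 `CON(C)C(=O)c1sc(-c2cccc(F)c2)nc1O` gives the lowest number of the three measured in an assay on HEK293 cells for inhibition of transient receptor potential cation channel subfamily M member 8 (Homo sapiens), read by FLIPR, with stated times of 5 min and 3 min (on this read-out lower numbers stand for stronger inhibition and higher numbers for weaker inhibition), with compound 2 at 96 nM; compound 1 `Cn1nnc(-c2sc(-c3cccc(F)c3)nc2O)n1` gives 214 nM and compound 3 `CCON(C)C(=O)c1sc(-c2cccc(F)c2)nc1O` gives 1680 nM. Compound 4 `Oc1nc(-c2cccc(F)c2)sc1-c1nn[nH]n1` differs from compound 2 by 2H-tetrazol-5-yl in place of methoxy(methyl)carbamoyl on an aromatic carbon. The closest guide is the step of a 2.2-fold lower number from compound 1 to compound 2 (0.35 log units; beyond the scatter), which compound 4 roughly reverses, though its 2H-tetrazol-5-yl carries a hydrogen-bond donor that the 2-methyl-2H-tetrazol-5-yl of compound 1 lacks. The step of an 18-fold higher number from compound 2 to compound 3 (1.24 log units; beyond the scatter) shows that small changes at this position can move the number a great deal. A modest rise is therefore expected, as a 3.1-fold higher number from compound 2 to compound 4 (0.49 log units; beyond the scatter), and compound 4 is estimated at 300 nM within a range of 100 nM to 1500 nM.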

Compound 4, half-maximal inhibitory concentration: > 100000 nM
Compound 4 gave a limit, no number (the forecaster's own chance of this, stated with the estimate: 5%); middle value at least 330-fold (2.52 log units) away from the limit.
By their numbers in this assay, from the lowest: compound 2; then compound 1; then compound 3. At a limit, above all of these: compound 4.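

In this assay compound 4 stands at a limit and not at a number: the limit of > 100000 nM in this assay, at which 1 of the 4 values shown sits. Hydrogen in place of methyl on an aromatic nitrogen alone gives an at least 460-fold higher number from compound 1 to compound 4 (2.66 log units; beyond the scatter), so among the compounds shown this position accepts the tetrazole only when that nitrogen carries methyl. The replacement of methoxy(methyl)carbamoyl by 2H-tetrazol-5-yl gives an at least 1000-fold higher number from compound 2 to compound 4 (3.01 log units; beyond the scatter), a far larger change than the methylated tetrazole had suggested. The compounds shown leave open whether the hydrogen on that nitrogen itself accounts for the loss. An ethyl on that nitrogen, or a carboxylic acid at this position, would help to separate the possibilities.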